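This account rests on a few compounds, and the source may have more. Where it says the series, first, only, none or still open, it means among the compounds named here.

Measured so far in a functional assay on RPMI-8226 cells (Homo sapiens) for cytotoxicity, read by MTT assay, with a stated time of 48 h; on this read-out higher numbers stand for weaker inhibition and lower numbers for stronger inhibition:
- Compound 1 `CC(C)(C)C(=O)NN=C1C(Cl)=C(Cl)C(Cl)=C1Cl`: 90 nM
- Compound 2 `CC(C)(C)OC(=O)NN=C1C(Cl)=C(Cl)C(Cl)=C1Cl`: 100 nM

On these numbers, compound 2 stands level with compound 1, since their two values lie within the scatter of each other. Compound 3 `CC(=O)NN=C1C(Cl)=C(Cl)C(Cl)=C1Cl` has not yet been measured. It differs from compound 2 by methyl in place of tert-butoxy on a carbonyl carbon.

Among the measured compounds shown here, only one measured step bears on this change. It is a 1.1-fold higher number from compound 1 to compound 2 (0.05 log units; within the scatter), with tert-butoxy in place of tert-butyl on a carbonyl carbon. That step stayed within the scatter, which gives a first hint that this place tolerates a change of group. For the measured compounds named here, the hint is thin, however, as no measured compound carries methyl there and a single step cannot set a direction. In this assay, then, no step beyond the scatter is expected, though the uncertainty is wide on either side. The estimate corresponds to an expected 1.2-fold higher number from compound 2 to compound 3 (0.08 log units; within the scatter). Compound 3 is expected at 120 nM, with an estimated range of 40 nM to 400 nM.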

Compound 3, half-maximal inhibitory concentration: 1000 nM
For compound 3 the middle estimate is 8.3-fold (0.92 log units) below the measured one; the whole stated range lies below it.
By their numbers in this assay, from the lowest: compounds 1 and 2 (each within the scatter of the next); then compound 3.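

In this assay, the place on a carbonyl carbon whose other neighbour is the amide-type nitrogen proves not to accept every group: methyl in place of tert-butoxy gives a 10-fold higher number from compound 2 to compound 3 (1.00 log units; beyond the scatter) and methyl in place of tert-butyl gives an 11-fold higher number from compound 1 to compound 3 (1.05 log units; beyond the scatter) as well. Among the compounds shown here, the earlier pair had exchanged only tert-butoxy and tert-butyl, two groups that stand level here, so the apparent tolerance held only for those two, and methyl is the first group at this place to move the number beyond the scatter. Nothing at hand gives a reason for this step.

On these data alone, what remains open is whether the weaker result belongs to methyl alone or would also appear with an ethyl or isopropyl group on the same carbonyl carbon, which would show how much of the tert-butyl or tert-butoxy group has to remain. As far as these compounds go, it is equally open whether a phenyl group or an amine at this place would stay level with compound 1 and compound 2 or fall towards compound 3.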